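Propyl to cyclopentyl on the amide of compound 2

A few compounds are considered here, and "the series" means these few. Any claim that something is new, unique, unknown or untested is made for them only; others in the source may bear on it.

Measured so far in a functional assay on Huh-7 cells (Homo sapiens) for antiproliferative activity, read by CCK-8 assay, with a stated time of 72 h; on this read-out lower numbers stand for stronger inhibition of growth and higher numbers for weaker inhibition of growth:
- compound 1 `CCCCNS(=O)(=O)c1ccc(Nc2ncc3c(n2)N(C2CCCC2)[C@H](CC)C(=O)N3C)cc1` gives 225 nM 
- compound 2 `CCCNC(=O)c1ccc2c(ccn2-c2ncc3c(n2)N(c2ccn(C)n2)C(CC)C(=O)N3C)c1` gives 7280 nM 

Compound 2, at 7280 nM in this assay, has the higher of the two numbers, and the gap down to compound 1, at 225 nM in the same read-out, lies beyond the scatter. These two compounds differ in more than one place, so their gap does not give the size of any single change.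

Compound 3 `CCC1C(=O)N(C)c2cnc(-n3ccc4cc(C(=O)NC5CCCC5)ccc43)nc2N1c1ccn(C)n1` departs from compound 2 in one place only, with cyclopentyl in place of propyl on an amide-type nitrogen (the same difference reads propylcarbamoyl to cyclopentylcarbamoyl). Going by the values given here, no measured pair shows this change, so the estimate starts from compound 2 at 7280 nM and stays close to it. In this assay the expected step of a 1.5-fold lower number from compound 2 to compound 3 (0.16 log units; within the scatter) is not expected to go beyond the scatter, with a slight lean toward a lower number. Among the compounds with values here, the range is kept wide, since no measured step supports the estimate. For compound 3 the estimated value is 5000 nM (expected range 1700 nM to 14000 nM).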

Compound 3, concentration for 50% growth inhibition: "not active" (no number reported)
Nothing numeric was reported for compound 3, so the estimate cannot be set against anything.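

Going by these compounds alone, compound 3 is recorded as "not active" with no number in this assay, so no step from compound 2 to compound 3 can be read. The compounds shown leave open how far cyclopentyl in place of propyl on the amide-type nitrogen shifts growth inhibition. No supporting data shown here bear on this result.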